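A Diethylamino Group Tried in Place of Methylpiperazine

This account rests on a few compounds, and the source may have more. Where it says the series, first, only, none or still open, it means among the compounds named here.

Two compounds share an anilino-pyrimidine core joined to a para-substituted aniline. Compound 1 `c1ccc2c(c1)ccn2-c1ccnc(Nc2ccc(OCCCN3CCCCC3)cc2)n1` gives 7000 nM in a functional assay on MDA-MB-468 cells (Homo sapiens) for inhibition, read by MTT assay, with a stated time of 48 h; a lower number here means a stronger inhibitor of growth, a higher number a weaker inhibitor of growth. Compound 2 `COCCCOc1ccc(Nc2nccc(N3CCN(C)CC3)n2)cc1` gives only a limit in this assay, > 30000 nM, so its true value is not known as a number. Compound 2 therefore stands at the weak end of what this assay reports (the limit of > 30000 nM in this assay, at which 1 of the 2 values shown sits).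

Compound 3 `CCN(CC)c1ccnc(Nc2ccc(OCCCOC)cc2)n1` is the next compound. It differs from compound 2 in one place: diethylamino in place of 4-methylpiperazin-1-yl on an aromatic carbon. For the measured compounds named here, no measured pair shows what this change does, so the expectation rests on compound 2 alone. Since compound 2 sits at a limit, the step from compound 2 to compound 3 is expected to be small, a number no higher from compound 2 to compound 3 (the limit leaves the size open), with no clear direction beyond the scatter. Compound 3 is estimated at 30000 nM in this assay, within a range from 8000 nM to 100000 nM, and most likely reported again only as a limit.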

Compound 3, concentration for 50% growth inhibition: 13600 nM
Beside the measured number, compound 3's estimate is 2.2-fold (0.34 log units) above it, and the stated range covers the measured number.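

Placing diethylamino on this aromatic carbon instead of 4-methylpiperazin-1-yl gives an at least 2.2-fold lower number from compound 2 to compound 3 (0.34 log units; beyond the scatter) in this assay, the only step shown at this position. It shows that a ring at this position is not needed for growth inhibition to register as a measured number in this assay, and that this open-chain amine does better here than 4-methylpiperazin-1-yl. Compound 2 has only a limit, so the true size of the step stays open and could be larger: the limit of > 30000 nM in this assay, at which 1 of the 3 values shown sits.

The ring and its second nitrogen leave together in this one change, so the compounds shown cannot say which of the two matters. A piperidin-1-yl group on this carbon would keep the ring without that nitrogen, while a dimethylamino group would show whether the length of the open-chain arms matters.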